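The compounds below may be only part of what the source reports. "The series", "measured", "known", "first", "only" and "open" are said of these compounds alone.

Measured so far:
- compound 1, `O=C(NCCCCc1ccccc1)n1c(=O)oc2cc(C3CCOCC3)ccc21`: 68 nM
- compound 2, `O=C(NCCCCc1ccccc1)n1c2c(oc1=O)CNCC2`: 340 nM

Both compounds were tested in an assay on HEK293 cells for inhibition of acid ceramidase (Homo sapiens), read by fluorescence, with stated times of 10 min and 3 h; on this read-out lower numbers stand for stronger inhibition and higher numbers for weaker inhibition. Compound 1 gives 68 nM, which is the lowest of the two numbers. Its nearest neighbour, compound 2, gives 340 nM, a higher number that lies beyond the usual scatter of repeated measurements, so compound 1 is the stronger inhibitor of the pair. Compound 2 differs from compound 1 in more than one place, so no single change can be read off from that gap.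

The next compound, compound 3, `CN1CCC(c2ccc3c(c2)oc(=O)n3C(=O)NCCCCc2ccccc2)CC1=O`, differs from compound 1 in one place only: 1-methyl-2-oxopiperidin-4-yl in place of oxan-4-yl on an aromatic carbon. Going by the values given here, no pair among the measured compounds isolates this kind of swap, so there is no measured step to lean on. The leaving and entering groups are of similar shape, both a six-membered non-aromatic ring with one hetero atom, and the change keeps the rest of compound 1 intact. In this assay the expected step is small, none beyond the scatter, and is expected to amount to a 1.3-fold higher number from compound 1 to compound 3 (0.10 log units; within the scatter). Compound 3 is therefore expected to give about 85 nM, within a range from 30 nM to 250 nM.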

Compound 3, half-maximal inhibitory concentration: 105 nM
Beside the measured number, compound 3's estimate is 1.2-fold (0.09 log units) below it; low and high end bracket the measured number.
By their numbers in this assay, from the lowest: compounds 1 and 3 (each within the scatter of the next); then compound 2.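

In this assay, putting 1-methyl-2-oxopiperidin-4-yl in place of oxan-4-yl on the aromatic carbon gives a 1.5-fold higher number from compound 1 to compound 3 (0.19 log units; within the scatter), so the two compounds cannot be told apart on this read-out. This is the first comparison shown in which only this position differs, something the gap between the first two compounds could not offer, since those compounds differ in more than one place. The entering group has 8 heavy atoms against 6 and adds a double bond outside aromatic rings, yet at this position, for this one swap, neither addition produces a step beyond the scatter, and no measurement shown here accounts for that.

A single swap between two similar six-membered non-aromatic rings says little about how far this position tolerates other kinds of group, such as a carboxylic acid, a primary amine or a simple phenyl ring. Going by these compounds alone, it also leaves open whether the same swap would give a similar result with a chain other than the one shared by these compounds, such as a longer chain on the urea nitrogen.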